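The source may report more compounds than this note shows. Statements on the series, on what has been measured and on what is new or still open speak of the compounds shown alone.

Measured compounds in a functional assay on HeLa cells (Homo sapiens) for inhibition, read by MTT assay, with a stated time of 72 h; on this read-out lower numbers stand for stronger inhibition and higher numbers for weaker inhibition:
compound 1 `CN(C(=O)NC(=O)c1cccc(C(F)(F)F)c1)c1nc(C(F)(F)F)c(C(=O)N/N=C/c2ccc(C(F)(F)F)cc2)s1` gives 7.35 ug/mL
compound 2 `CN(C(=O)NC(=O)c1cccc(C(F)(F)F)c1)c1nc(C(F)(F)F)c(C(=O)N/N=C/c2ccccc2C(F)(F)F)s1` gives 7.37 ug/mL
compound 3 `CN(C(=O)NC(=O)c1c(F)cccc1F)c1nc(C(F)(F)F)c(C(=O)N/N=C/c2ccc(C(F)(F)F)cc2)s1` gives 30.6 ug/mL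

Compound 4 `CN(C(=O)NC(=O)c1c(F)cccc1F)c1nc(C(F)(F)F)c(C(=O)N/N=C/c2ccccc2C(F)(F)F)s1` is not yet measured. It differs from compound 3 by 2-(trifluoromethyl)phenyl in place of 4-(trifluoromethyl)phenyl on a carbon with a double bond to nitrogen. Exactly the same change, at the same place, links the two measured compounds 1 and 2: 2-(trifluoromethyl)phenyl in place of 4-(trifluoromethyl)phenyl on a carbon with a double bond to nitrogen. There it made a 1.0-fold higher number from compound 1 to compound 2 (0.00 log units; within the scatter), so swapping the two trifluoromethylphenyl groups left the result essentially unchanged. Compounds 3 and 4 carry a different core from compounds 1 and 2; that core difference is 2,6-difluorophenyl in place of 3-(trifluoromethyl)phenyl on a carbonyl carbon, and it made a 4.2-fold higher number from compound 1 to compound 3 (0.62 log units; beyond the scatter). Within the data shown here, since the only change from compound 3 to compound 4 is the one that made no difference between compound 1 and compound 2, the expected step is a 1.0-fold lower number from compound 3 to compound 4 (0.01 log units; within the scatter), a step within the scatter. Compound 4 is therefore estimated at 30 ug/mL, most likely between 15 ug/mL and 60 ug/mL.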

Compound 4, half-maximal inhibitory concentration: 19.6 ug/mL
Compound 4: middle estimate off by 1.5-fold (0.18 log units), on the high side; low and high end bracket the measured number.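

In this assay, putting 2-(trifluoromethyl)phenyl in place of 4-(trifluoromethyl)phenyl gives a 1.6-fold lower number from compound 3 to compound 4 (0.19 log units; within the scatter), and this can be set beside the same swap on the core of compound 1: the same change on two cores in this assay, a 1.0-fold higher number (0.00 log units; within the scatter) from compound 1 to compound 2 and a 1.6-fold lower number (0.19 log units; within the scatter) from compound 3 to compound 4, 1.6-fold (0.19 log units) apart, within the scatter of two such steps. Putting 2,6-difluorophenyl in place of 3-(trifluoromethyl)phenyl on the carbonyl carbon gives a 2.7-fold higher number from compound 2 to compound 4 (0.42 log units; beyond the scatter), and this too matches its earlier counterpart: the same change on two cores in this assay, a 4.2-fold higher number (0.62 log units; beyond the scatter) from compound 1 to compound 3 and a 2.7-fold higher number (0.42 log units; beyond the scatter) from compound 2 to compound 4, 1.6-fold (0.19 log units) apart, within the scatter of two such steps. So each change behaved alike on the two cores in this one assay, but two cores cannot show that it would carry over to a third.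

The compounds shown leave open what a plain phenyl or a methoxyphenyl group would do on the carbon with a double bond to nitrogen. They also leave open whether these steps would hold in any other assay.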